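From 2-aminophenyl to 3-chlorophenyl in a cytotoxicity series

The compounds below may be only part of what the source reports. "The series", "measured", "known", "first", "only" and "open" are said of these compounds alone.

Measured so far in a toxicity assay on NIH3T3 cells (Mus musculus) for cytotoxicity, read by resazurin assay; on this read-out lower numbers stand for an effect already at smaller amounts and higher numbers for an effect only at larger amounts of compound:
compound 1, `COC(=O)c1ccc(NCc2cncn2Cc2ccccc2N)cc1-c1ccccc1`: 25000 nM
compound 2, `c1ccc(-c2ccc(Cn3cncc3CNc3ccc(-c4noc5ccccc45)c(-c4ccccc4)c3)cc2)cc1`: > 10000 nM

Going by the values given here, compound 1 holds the only plain number among the two values shown; in this assay compound 1 gives 25000 nM. For compound 2 the assay reports no number but only a limit, > 10000 nM, namely (the limit of > 10000 nM in this assay, at which 1 of the 2 values shown sits).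

Compound 3, `COC(=O)c1ccc(NCc2cncn2Cc2cccc(Cl)c2)cc1-c1ccccc1`, has not yet been measured. It differs from compound 1 in one place:
3-chlorophenyl in place of 2-aminophenyl on a saturated chain carbon bound to an aromatic nitrogen
Among the compounds with values here, no step between two measured compounds is available, so the size of this change cannot be read from a neighbouring pair. The exchange is expected to move the result of this assay only a little, at most marginally beyond the usual scatter, so the step of a 1.3-fold lower number from compound 1 to compound 3 (0.10 log units; within the scatter) is the expected outcome. For compound 3 the estimate is 20000 nM, expected to fall between 7000 nM and 50000 nM.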

Compound 3, half-maximal effective concentration: > 10000 nM
Compound 3: only a limit was reported (the forecaster's own chance of this, stated with the estimate: 25%); the middle value lies beyond the limit too.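

In this assay compound 3 returns only a limit, so no step from compound 1 to compound 3 can be read: the limit of > 10000 nM in this assay, at which 2 of the 3 values shown sit.

The compounds shown leave open whether 3-chlorophenyl in place of 2-aminophenyl changes this result at all, and in which direction.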